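This account rests on a few compounds, and the source may have more. Where it says the series, first, only, none or still open, it means among the compounds named here.

Measured in a functional assay on HCT-116 cells (Homo sapiens), read by MTT assay, with a stated time of 72 h (on this read-out lower numbers stand for stronger inhibition and higher numbers for weaker inhibition), all three values being limits:
compound 1 `CNc1ncnc2c1c(-c1ccccc1)cn2[C@@H]1O[C@H](CO)[C@@H](O)[C@H]1O`: > 100000 nM
compound 2 `Cc1ncnc2c1c(-c1cc3ccccc3o1)cn2[C@@H]1O[C@H](CO)[C@@H](O)[C@H]1O`: > 20000 nM
compound 3 `Nc1nc2c(c(-c3ccco3)cn2[C@@H]2O[C@H](CO)[C@@H](O)[C@H]2O)c(=O)[nH]1`: > 20000 nM

Compound 3 stands at the limit of > 20000 nM in this assay, at which 2 of the 3 values shown sit. Compound 4 `Nc1nc2c(c(-c3cc4ccccc4o3)cn2[C@@H]2O[C@H](CO)[C@@H](O)[C@H]2O)c(=O)[nH]1` carries 1-benzofuran-2-yl in place of furan-2-yl on an aromatic carbon. Compound 2 also carries 1-benzofuran-2-yl, and its > 20000 nM is a limit. In this assay no step beyond the usual scatter is expected, in either direction. The expected size is a step that the limit leaves unreadable from compound 3 to compound 4, an estimate that rests on a limit and not on a number. For compound 4 the estimate is 25000 nM, with an expected range of 10000 nM to 100000 nM, and a limit is the likelier report.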

Compound 4, half-maximal inhibitory concentration: > 100000 nM
Compound 4: only a limit was reported; the forecaster's own chance of this, stated with the estimate: 85%; at least 4.0-fold (0.60 log units) between middle value and limit.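

In this assay compound 3 is reported only as the limit > 20000 nM. Compound 4 is likewise only the limit > 100000 nM, so no step can be read between these two compounds. The compounds shown leave open whether 1-benzofuran-2-yl in place of furan-2-yl changes inhibition at all.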